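Aryl swap on the chalcone amide: expectation for compound 3

The source may report more compounds than this note shows. Statements on the series, on what has been measured and on what is new or still open speak of the compounds shown alone.

Two measured members exist so far. Within the data shown here, compound 1 `O=C(COc1ccc(C(=O)/C=C/c2cccc(Cl)c2)cc1)N[C@H]1CCOC1=O` and compound 2 `O=C1OCC[C@@H]1NC(=S)SCCOc1ccccc1[N+](=O)[O-]` share the lactone amine but differ in many places, so no single step between measured compounds is available. In a functional assay on MGC-803 cells (Homo sapiens) for antiproliferative activity, read by MTT assay, with a stated time of 72 h (a higher number here means a weaker inhibitor, a lower number a stronger inhibitor), compound 1 gives 29100 nM; in this assay compound 2 gives 47000 nM. The gap between the two lies within the scatter, so no order is claimed; compound 1 simply holds the lower of the two numbers.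

Compound 3 `CC(C)c1ccc(/C=C/C(=O)c2ccc(OCC(=O)N[C@H]3CCOC3=O)cc2)cc1` changes compound 1 in one place: 4-isopropylphenyl in place of 3-chlorophenyl on a double-bonded chain carbon bound to a double-bonded chain carbon. Nothing measured in the series speaks to this change, so no step beyond the scatter is expected in either direction. The estimate for compound 3 in this assay is 25000 nM, with a range from 8000 nM to 80000 nM. The expected step of a 1.2-fold lower number from compound 1 to compound 3 (0.07 log units; within the scatter) is taken to lie within the scatter.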

Compound 3, half-maximal inhibitory concentration: 16800 nM
Compound 3: the middle estimate sits 1.5-fold (0.17 log units) above what was measured; the measured number falls inside the stated range.
By their numbers in this assay, from the lowest: compounds 3, 1 and 2 (each within the scatter of the next, the first and the last beyond it).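

In this assay, among these compounds, the swap to 4-isopropylphenyl in place of 3-chlorophenyl, on a double-bonded chain carbon bound to a double-bonded chain carbon, gives a 1.7-fold lower number from compound 1 to compound 3 (0.24 log units; within the scatter) and is the first single-place step. This place therefore accepts an all-carbon 4-isopropylphenyl with no step beyond the scatter, and the chlorine of compound 1 is not required to keep a number of this size. No measurement on hand bears on the reason for this result.

Still open, on these data alone, is whether a phenyl ring carrying an amine or a carboxylic acid at this place would move the number beyond the scatter. Among the compounds shown here, the single swap also leaves the contribution of removing the chlorine unseparated from that of adding the isopropyl group.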